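Fluorine for Methyl on the Outer Phenyl Ring

The source may hold more compounds than are shown below. What is called first, only, known or untested is meant among the compounds shown, and "the series" means these compounds.

Compounds measured in a functional assay on HT-29 cells (Homo sapiens) for cytotoxicity, read by MTT assay, with a stated time of 72 h; a lower number here means a stronger inhibitor, a higher number a weaker inhibitor:
Compound 1 `COc1cc2c(Oc3ccc(NC(=O)c4cc(-c5ccccc5)ccn4)cc3F)ccnc2cc1OCCCN1CCN(C)CC1` gives 82 nM.
Compound 2 `COc1cc2c(Oc3ccc(NC(=O)c4cc(-c5ccc(F)cc5)ccn4)cc3F)ccnc2cc1OCCCN1CCCCC1` gives 1370 nM.
Compound 3 `COc1cc2c(Oc3ccc(NC(=O)c4cc(-c5ccc(C)cc5)ccn4)cc3F)ccnc2cc1OCCCN1CCCC1` gives 350 nM.

Compound 3 stands second highest of the three numbers; its nearest neighbour is compound 2, whose number is higher by a margin beyond the scatter, and the furthest is compound 1, whose number is lower by a margin beyond the scatter. Compound 4 `COc1cc2c(Oc3ccc(NC(=O)c4cc(-c5ccccc5F)ccn4)cc3F)ccnc2cc1OCCCN1CCCC1` has not yet been measured in this assay. For the measured compounds named here, its only difference from compound 3 is 2-fluorophenyl in place of 4-methylphenyl on an aromatic carbon, the site lying meta to a large group and opposite the ring nitrogen. Going by the values given here, no single-change pair between measured compounds exists, so the step from compound 3 to compound 4 is expected to be small, within the scatter or a slight weakening, giving a 1.2-fold higher number from compound 3 to compound 4 (0.08 log units; within the scatter). For compound 4 the estimate in this assay is 420 nM, with a range from 130 nM to 1400 nM.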

Compound 4, half-maximal inhibitory concentration: 230 nM
Beside the measured number, compound 4's estimate is 1.8-fold (0.26 log units) above it; the measured number falls inside the stated range.
By their numbers in this assay, from the lowest: compound 1; then compounds 4 and 3 (each within the scatter of the next); then compound 2.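

In this assay, putting 2-fluorophenyl in place of 4-methylphenyl on this aromatic carbon, opposite the ring nitrogen, gives a 1.5-fold lower number from compound 3 to compound 4 (0.18 log units; within the scatter). This first single-change pair shows that the position accepts this exchange of outer rings without a change that can be told from the scatter. No measurement shown here accounts for the result.

Because the substituent and its place on the outer phenyl ring change together, the pair cannot separate the two. On these data alone, how a carboxylic acid or an amine on that ring would read remains open.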